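The source may report more compounds than this note shows. Statements on the series, on what has been measured and on what is new or still open speak of the compounds shown alone.

Working notes on the series in a functional assay on MCF7 cells (Homo sapiens) for cytotoxicity, read by MTT assay, with a stated time of 72 h; a higher number here means a weaker inhibitor, a lower number a stronger inhibitor. Compound 1 `COc1ccc(/C=C2\CCC/C(=C\c3cccc(OC)c3OC)C2=O)cc1OC` gives 6500 nM, compound 2 `COc1ccc(/C=C2\CCC/C(=C\c3ccc(Cl)cc3)C2=O)cc1OC` gives 6300 nM and compound 3 `COc1ccc(/C=C2\CCC/C(=C\c3ccc(Br)cc3)C2=O)cc1OC` gives 6900 nM. All three lie within the scatter of each other, so compound 3 stands level with the other two.

The next change leads to compound 4 `COc1ccc(/C=C2\CCC/C(=C\c3ccc(O)cc3)C2=O)cc1OC`: hydroxy in place of bromo on an aromatic carbon, para to a large group. Among the compounds with values here, the one measured step that bears on it is a 1.1-fold higher number from compound 2 to compound 3 (0.04 log units; within the scatter), which exchanges chloro for bromo and stays within the scatter. Compound 1, which carries no halogen, also sits at this level with 6500 nM. Within the data shown here, no measured compound carries a hydroxy group on this ring, so the direction remains open, and no step beyond the scatter is expected in this assay. The estimated step is a 1.3-fold lower number from compound 3 to compound 4 (0.10 log units; within the scatter). For compound 4 the estimated value is 5500 nM, with an expected range of 2000 nM to 12000 nM.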

Compound 4, half-maximal inhibitory concentration: 17000 nM
Compound 4: the middle estimate sits 3.1-fold (0.49 log units) below what was measured, and the stated range ends below it.
By their numbers in this assay, from the lowest: compounds 2, 1 and 3 (each within the scatter of the next); then compound 4.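

Position para to a large group on this ring does respond to substitution in this assay: the change from 4-bromophenyl to 4-hydroxyphenyl gives a step beyond the scatter (a 2.5-fold higher number from compound 3 to compound 4 (0.39 log units; beyond the scatter)), and the chloro compound gives the same picture (a 2.7-fold higher number from compound 2 to compound 4 (0.43 log units; beyond the scatter)). Within the data shown here, the exchange between the two halogens stayed within the scatter (a 1.1-fold higher number from compound 2 to compound 3 (0.04 log units; within the scatter)), so hydroxy is the first replacement here that separates from the halogens, and it does so towards a weaker number. Nothing measured here explains this step.

Going by these compounds, it remains open whether the weaker number belongs to hydroxy alone or extends to other groups at this place, such as an amine or a carboxylic acid. A methyl ether or an unsubstituted phenyl at the same place would also show whether the halogens or the hydroxy group set the level.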